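A Second Methyl on a Weak Compound

This account rests on a few compounds, and the source may have more. Where it says the series, first, only, none or still open, it means among the compounds named here.

Compound 1 `O=C1Nc2ccccc2C1(c1ccc(O)cc1)C1CCCCCC1`: 247 nM
Compound 2 `Cc1cccc2c1NC(=O)C2(c1ccc(O)cc1)C1CCCCCC1`: > 1000 nM (a limit)
Compound 3 `Cc1cc(C)c2c(c1)C(c1ccc(O)cc1)(C1CCCCCC1)C(=O)N2`: > 1000 nM (a limit)

The measurements come from a functional assay on MCF7 cells (Homo sapiens) for cytotoxicity, read by WST assay, with a stated time of 72 h; on this read-out lower numbers stand for stronger inhibition and higher numbers for weaker inhibition. Only compound 1 has a true number here. Compound 2 stands at > 1000 nM, which is a limit of the assay and not a number. Compound 3 reads > 1000 nM, and this too is a limit. Much of the picture therefore rests on (the limit of > 1000 nM in this assay, at which 2 of the 3 values shown sit).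

Compound 4 `Cc1ccc2c(c1C)NC(=O)C2(c1ccc(O)cc1)C1CCCCCC1` comes from compound 2 through a single change: methyl in place of hydrogen on an aromatic carbon. The new methyl sits ortho to the methyl group already in place. Two measured steps in this assay bear on this, and both are the same kind of change. The first is an at least 4.0-fold higher number from compound 1 to compound 2 (0.60 log units; beyond the scatter), a move toward weaker inhibition that lies beyond the scatter. The second is a step that the two limits leave unreadable from compound 2 to compound 3. Neither step shows a methyl bringing inhibition back.

Within the data shown here, compound 4 is expected to stay weak, since the one readable methyl step was an at least 4.0-fold higher number from compound 1 to compound 2 (0.60 log units; beyond the scatter). The expected change is a step that the limit leaves unreadable from compound 2 to compound 4, and it may not be readable if only a limit is reported. For compound 4 the estimated value is 2000 nM, with an expected range of 700 nM to 8000 nM.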

Compound 4, half-maximal inhibitory concentration: 19 nM
Compound 4: the middle estimate sits 110-fold (2.02 log units) above what was measured; measured number outside the range, below it.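

The same change, methyl in place of hydrogen on an aromatic carbon, can go in opposite directions in this assay: the earlier readable case was an at least 4.0-fold higher number from compound 1 to compound 2 (0.60 log units; beyond the scatter), a move toward weaker inhibition, while the new one is an at least 52-fold lower number from compound 2 to compound 4 (1.72 log units; beyond the scatter), a large move toward stronger inhibition. This position, ortho to a methyl group and meta to a fused ring, is therefore the first one shown where an added methyl brings inhibition back, so the count of methyl groups alone does not set the outcome, and the step from compound 2 to compound 3 cannot be read. Compound 2 reads > 1000 nM, which is a limit and not a number, so the size of the new step is only a floor, and part of the picture still rests on that limit: the limit of > 1000 nM in this assay, at which 2 of the 4 values shown sit.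

The compounds shown leave open whether a methyl at this position would bring the same gain without the methyl group already in place on compound 2. They also leave open whether a chlorine atom, a methoxy group or an amine at this position would behave like the methyl.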